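An Amide Replaces an Amine on a Macrocyclic Enone

The source may hold more compounds than are shown below. What is called first, only, known or untested is meant among the compounds shown, and "the series" means these compounds.

Compound 1 `CC(C)=CCC[C@]1(C)/C=C/[C@@H](OC(=O)C=C(C)C)[C@](C)(O)/C=C/C(=O)/C(CN(C(C)C)C(C)C)=C\C1` gives, in a functional assay on MCF7 cells (Homo sapiens) for antiproliferative activity, read by MTT assay, with a stated time of 48 h (a lower number here means a stronger inhibitor, a higher number a weaker inhibitor), a value of 780 nM, the lowest number among the compounds measured, while compound 3 `CC(C)=CCC[C@]1(C)/C=C/[C@@H](OC(=O)C=C(C)C)[C@](C)(O)/C=C/[C@H](O)/C(CO)=C\C1` gives 33000 nM. Compound 2 `CC(C)=CCC[C@]1(C)/C=C/[C@@H](OC(=O)C=C(C)C)[C@](C)(O)CCC(=O)/C(CO)=C\C1` reaches only the limit of this assay, > 40000 nM, so no number is known for it. Of the three values, one sits at the limit of > 40000 nM in this assay, at which 1 of the 3 values shown sits. Compound 4 `CC(C)=CCC[C@]1(C)/C=C/[C@@H](OC(=O)C=C(C)C)[C@](C)(O)/C=C/C(=O)/C(C(=O)N2CCCC2)=C\C1` has not been measured yet. It differs from compound 1 in a single place: (pyrrolidin-1-yl)carbonyl in place of (diisopropylamino)methyl on a double-bonded ring carbon. Among the measured compounds shown here, no measured pair shows a change of this kind, so the size of the step is uncertain. Compound 4 is expected to give a somewhat higher number, estimated at 3000 nM within a range from 700 nM to 15000 nM. That estimate means an expected step of a 3.8-fold higher number from compound 1 to compound 4 (0.59 log units; beyond the scatter), modest and possibly within the scatter.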

Compound 4, half-maximal inhibitory concentration: 17200 nM
For compound 4 the middle estimate is 5.7-fold (0.76 log units) below the measured one, outside the stated range (above it).
By their numbers in this assay, from the lowest: compound 1; then compounds 4 and 3 (each within the scatter of the next). At a limit, above all of these: compound 2.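

Among the compounds shown here, putting (pyrrolidin-1-yl)carbonyl in place of (diisopropylamino)methyl gives a 22-fold higher number from compound 1 to compound 4 (1.34 log units; beyond the scatter) in this assay and is the first single-place comparison in this set. It shows that the group on this double-bonded ring carbon can, by itself, move the number well beyond the scatter while the rest of compound 1 stays the same. Nothing measured here accounts for this large step.

The change alters the ring, the carbonyl and the amine together, so the compounds shown cannot separate their contributions. A (pyrrolidin-1-yl)methyl group on this carbon would help to separate them.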